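The source may report more compounds than this note shows. Statements on the series, on what has been measured and on what is new or still open speak of the compounds shown alone.

Measured compounds:
Compound 1 `CCON(C)C(=O)c1sc(-c2ccccc2O)nc1O`, 1500 nM
Compound 2 `CCn1nnc(-c2sc(-c3ccccc3O)nc2O)n1`, 24 nM
Compound 3 `CSc1cc(-c2ccc(Cl)cc2)[nH]n1`, 977 nM

In an assay on HEK293 cells for inhibition of transient receptor potential cation channel subfamily M member 8 (Homo sapiens), read by FLIPR, with stated times of 5 min and 3 min (a lower number here means a stronger inhibitor, a higher number a weaker inhibitor), compound 2 gives 24 nM, the lowest of the three numbers. Compound 3 gives 977 nM, and compound 1 gives 1500 nM; both of these stand well beyond the scatter from compound 2, so compound 2 is the strongest inhibitor shown.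

Compound 4 `CCn1nnc(-c2sc(-c3ccccc3OC)nc2O)n1` is not yet measured in this assay. Relative to compound 2 the difference is methyl in place of hydrogen on an oxygen on an aromatic ring. For the measured compounds named here, no pair of measured compounds differs by this kind of change, so there is no measured step to lean on; the only guide is that compound 2 carries the free hydroxy and sits far from the other two.

Expectation for compound 4: a weakening in this assay beyond the scatter, but not back to the level of compound 1 or compound 3; the step from compound 2 is estimated at a 17-fold higher number from compound 2 to compound 4 (1.22 log units; beyond the scatter). Compound 4 is thus estimated at 400 nM, with a range from 80 nM to 2000 nM.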

Compound 4, half-maximal inhibitory concentration: 2790 nM
Estimate against measurement, compound 4: 7.0-fold (0.84 log units) below; the measured number lies above the stated range.
By their numbers in this assay, from the lowest: compound 2; then compounds 3, 1 and 4 (each within the scatter of the next, the first and the last beyond it).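

In this assay, the change from hydroxy to methoxy on the aromatic ring gives a 120-fold higher number from compound 2 to compound 4 (2.07 log units; beyond the scatter), a large loss of inhibition from a single added methyl. For the compounds shown here, this is the first direct reading at this position, and it shows that the oxygen on the aromatic ring is highly sensitive to replacing its hydrogen, at least with methyl and with the ethyl tetrazole-bearing side of compound 2 held constant. Nothing available here accounts for the size of this loss.

As far as these compounds go, whether the loss follows from losing the hydrogen or from adding the methyl remains open, and an amine or a fluorine in place of the hydroxy would help separate the two. Also open, from the compounds shown here alone, is whether a longer chain on that oxygen, such as ethyl, behaves like methyl, and whether the same step holds with the side group of compound 1.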